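The compounds below may be only part of what the source reports. "The series", "measured", "known", "first", "only" and "open" are said of these compounds alone.

In a physicochemical assay for lipophilicity (a lower number here means a more polar compound, a higher number a more lipophilic compound), compound 3 `COc1cccc2c1c(NS(=O)(=O)c1ccc(Cl)c(Cl)c1)nn2Cc1cccc(CNC(=O)C(C)(C)O)c1` stands highest of the three measured compounds at 5.1, against compound 1 `COc1cccc2c1c(NS(=O)(=O)c1ccc(Cl)s1)nn2Cc1cccc(CNC(=O)C2CCOCC2)c1` at 4.4 and compound 2 `COc1cccc2c1c(NS(=O)(=O)c1ccc(Cl)s1)nn2Cc1cccc(CNC(=O)C(C)(C)N)c1` at 3.3. Compound 4 `COc1cccc2c1c(NS(=O)(=O)c1cccc(Cl)c1Cl)nn2Cc1cccc(CNC(=O)C(C)(C)O)c1` keeps the same atoms, joined differently: 2,3-dichlorophenyl in place of 3,4-dichlorophenyl on a sulfonyl sulfur. The change puts 2,3-dichlorophenyl in place of 3,4-dichlorophenyl on a sulfonyl sulfur. Going by the values given here, the one measured step, a number 1.10 log units lower from compound 1 to compound 2 (beyond the scatter), is large but lies on a carbonyl carbon, so it gives no size for this change. Among the compounds with values here, no measured step touches the sulfonyl sulfur, and the counted features stay equal, so no step beyond the scatter is expected in this assay. The expected step of a number 0.10 log units lower from compound 3 to compound 4 (within the scatter) stays within the scatter. Compound 4 is estimated at 5, with an expected range of 4.6 to 5.4.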

Compound 4, distribution coefficient: 4.7
Estimate against measurement, compound 4: 0.30 log units above; measured number inside the range.
By their numbers in this assay, from the lowest: compound 2; then compounds 1 and 4 (each within the scatter of the next); then compound 3.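

In this assay, moving the chlorines alone registers at the sulfonyl sulfur: 2,3-dichlorophenyl in place of 3,4-dichlorophenyl gives a number 0.40 log units lower from compound 3 to compound 4 (beyond the scatter) with no change in the counted features. This is the only measured size for a change at this position, as the earlier step lay on a carbonyl carbon. Nothing measured here accounts for the step. Still open, on these data alone, is where 3,5-dichlorophenyl on the sulfonyl sulfur would stand, and whether the step persists with 1-amino-1-methylethyl on the carbonyl carbon.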